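The source may report more compounds than this note shows. Statements on the series, on what has been measured and on what is new or still open speak of the compounds shown alone.

Working notes on the series. Compound 1 `COc1cccc(/C=C/C(=O)Nc2cc(OC)c(OC)c(OC)c2)c1` gives 3200 nM in a functional assay on DU-145 cells (Homo sapiens) for cytotoxicity, read by MTT assay, with a stated time of 72 h; a lower number here means a stronger inhibitor, a higher number a weaker inhibitor. Among the compounds with values here, compound 2 `C#CCOc1cccc(/C=C/C(=O)Nc2cc(C(=O)c3cc(OC)c(OC)c(OC)c3)ccc2OC)c1`, which carries a 3-(propargyloxy)phenyl on the chain, gives 15800 nM in this assay and so stands highest of the three numbers known, with compound 3 as its nearest neighbour and compound 1 furthest from it. Within the data shown here, compound 3 `COc1ccc(C(=O)c2cc(OC)c(OC)c(OC)c2)cc1NC(=O)/C=C/c1ccc(F)cc1` gives 3900 nM in this assay, and the one measured step bearing on the question here is a 4.1-fold lower number from compound 2 to compound 3 (0.61 log units; beyond the scatter).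

The next compound, compound 4 `COc1ccc(C(=O)c2cc(OC)c(OC)c(OC)c2)cc1NC(=O)/C=C/c1ccc(F)c(F)c1`, differs from compound 2 by 3,4-difluorophenyl in place of 3-(propargyloxy)phenyl on a double-bonded chain carbon bound to a double-bonded chain carbon. Among the measured compounds shown here, the change resembles the step to compound 3, with a second fluorine on the ring as the only further difference, and no measured pair speaks to that second fluorine on its own. The expectation therefore leans on the measured step from compound 2 to compound 3, and the expected step is a 4.2-fold lower number from compound 2 to compound 4 (0.62 log units; beyond the scatter). For compound 4 the estimate in this assay is 3800 nM, with a range from 1500 nM to 10000 nM.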

Compound 4, half-maximal inhibitory concentration: 10200 nM
For compound 4 the middle estimate is 2.7-fold (0.43 log units) below the measured one, and the stated range ends below it.
By their numbers in this assay, from the lowest: compounds 1 and 3 (each within the scatter of the next); then compounds 4 and 2 (each within the scatter of the next).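

In this assay, within the data shown here, the added fluoro on an aromatic carbon can be read on its own for the first time, and it gives a 2.6-fold higher number from compound 3 to compound 4 (0.42 log units; beyond the scatter), so the ring substituents at this place on the chain are not interchangeable. The change from 3-(propargyloxy)phenyl to 3,4-difluorophenyl gives only a 1.5-fold lower number from compound 2 to compound 4 (0.19 log units; within the scatter), so the larger step from compound 2 to compound 3 does not carry over to every fluorinated phenyl at this place. Nothing available explains why the added fluoro raises the number.

Open, from the compounds shown here alone, is whether a chloro in place of the added fluoro would give a similar step, or whether the step is specific to fluoro. Also open, going by these compounds, is how an amine or a carboxylic acid on this phenyl would read against compound 3 and compound 4.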